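Trimming a Methoxy Group: Expected Cytotoxicity of Compound 4

This account rests on a few compounds, and the source may have more. Where it says the series, first, only, none or still open, it means among the compounds named here.

Three close relatives sharing one core were tested in a functional assay on UACC-257 cells (Homo sapiens) for cytotoxicity, read by sulforhodamine B assay, with a stated time of 48 h, tested at 0.1 uM; on this read-out higher numbers stand for a weaker effect at the one concentration tested and lower numbers for a stronger effect. Compound 1 `COc1ccc(-c2cc(/C=C/C(=O)c3ccc(N)cc3)[nH]n2)cc1` gives 97% in this assay. Compound 2 `COc1cc(-c2cc(/C=C/C(=O)c3ccc(N)cc3)[nH]n2)cc(OC)c1OC` gives 93%, and compound 3 `COc1ccc(C(=O)/C=C/c2cc(-c3cc(OC)c(OC)c(OC)c3)n[nH]2)cc1` gives 97%. Going by the values given here, of the three numbers, the one for compound 2 is the smallest, yet compound 1 and compound 3 both sit within the usual scatter of it, so none of the three can be singled out as stronger or weaker. Among the compounds with values here, the only single-site step among them runs from compound 2 to compound 3, where a methoxy replaces an amino group on an aromatic carbon: a number 4 percentage points higher from compound 2 to compound 3 (within the scatter).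

The unmeasured compound 4 `COc1ccc(-c2cc(/C=C/C(=O)c3ccc(N)cc3)[nH]n2)cc1OC` differs from compound 2 at one place: hydrogen in place of methoxy on an aromatic carbon. Within the data shown here, no measured step touches this methoxy group, so the only guidance is the flat picture overall, in which the one change at a different aromatic carbon stayed within the scatter. The expectation is therefore a step of a number 3 percentage points higher from compound 2 to compound 4 (within the scatter), nothing beyond the scatter. Compound 4 is expected to give about 96%, between 86% and 104%.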

Compound 4, a percentage reported as activity, at one concentration (the size of the read-out at that concentration, not a potency): 90%
The estimate for compound 4 lay 6 percentage points above the measured number; low and high end bracket the measured number.
By their numbers in this assay, from the lowest: compounds 4, 2, 1 and 3 (each within the scatter of the next).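

In this assay, this position, on a six-membered aromatic ring of carbon only, ortho to a methoxy group and meta to a large group, now has steps of its own: hydrogen in place of methoxy gives a number 3 percentage points lower from compound 2 to compound 4 (within the scatter) and methoxy in place of hydrogen gives a number 7 percentage points lower from compound 1 to compound 4 (within the scatter) on the same ring. Seen from both directions, then, having or lacking a methoxy group at this position produces no step beyond the scatter, at the single concentration tested. No measurement shown here offers a reason for these numbers.

Still open, as far as these compounds go, is whether a hydroxy group, a chlorine atom or a longer chain such as ethoxy at this position would give a step beyond the scatter. Also open, from the compounds shown here alone, is whether the methoxy change would stay this small at other concentrations.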